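The source may report more compounds than this note shows. Statements on the series, on what has been measured and on what is new or still open speak of the compounds shown alone.

Measured compounds:
Compound 1 `COc1ccc(C(=O)N/N=C(C)/C=N/Nc2ccc([N+](=O)[O-])cc2)cc1` gives > 100000 nM in an ADME assay on J774 cells (Mus musculus, strain BALB/c) for cytotoxicity, read by resazurin assay, with a stated time of 72 h (on this read-out higher numbers stand for lower toxicity in this test and lower numbers for higher toxicity in this test), which is a limit of the assay and not a number.
Compound 2 `COc1cc(C(=O)N/N=C(C)/C=N/Nc2ccc([N+](=O)[O-])cc2)ccc1O` gives > 100000 nM in this assay, again a limit of the assay.
Compound 3 `CC(/C=N/Nc1ccc([N+](=O)[O-])cc1)=N\NC(=O)c1ccc(C(F)(F)F)cc1` gives 78700 nM in this assay.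

For the measured compounds named here, compound 3 thus carries the only number among the three values shown. Compounds 1 and 2 sit at the limit of > 100000 nM in this assay, at which 2 of the 3 values shown sit. The unmeasured compound 4 `CC(/C=N/Nc1ccc([N+](=O)[O-])cc1)=N\NC(=O)c1ccccc1` differs from compound 3 by hydrogen in place of trifluoromethyl on an aromatic carbon. The measured step at the same aromatic carbon is an at least 1.2-fold lower number from compound 1 to compound 3 (0.10 log units; that floor lies within the scatter), which lies within the scatter, and a step that the two limits leave unreadable from compound 1 to compound 2 is unreadable. Going by the values given here, none of the measured steps points to a shift beyond the scatter for hydrogen in place of trifluoromethyl, so in this assay compound 4 is expected to sit close to compound 3, if anything drifting toward the limit. The step expected is a 1.3-fold higher number from compound 3 to compound 4 (0.10 log units; within the scatter). Compound 4 is estimated at 100000 nM in this assay, with a range from 50000 nM to 200000 nM.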

Compound 4, half-maximal cytotoxic concentration: > 100000 nM
Compound 4: no number, only a limit; the forecaster's own chance of this, stated with the estimate: 50%; the middle value lies on the limit itself.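

In this assay, hydrogen in place of trifluoromethyl on this aromatic carbon, para to a large group, gives an at least 1.2-fold higher number from compound 3 to compound 4 (0.10 log units; that floor lies within the scatter), so this change shows no shift beyond the scatter. For the compounds shown here, with the unsubstituted phenyl now at the limit alongside the methoxy and 4-hydroxy-3-methoxyphenyl compounds, trifluoromethyl remains the only group here with a readable number: the limit of > 100000 nM in this assay, at which 3 of the 4 values shown sit. The steps from compound 1 and from compound 2 to compound 4 join two limits and cannot be read.

On these data alone, it remains open whether any group on this aromatic carbon, such as an amine, a carboxylic acid or a longer chain, would move the number beyond the scatter in this assay. As far as these compounds go, how compound 1, compound 2 and compound 4 rank among themselves also stays unknown.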